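This account rests on a few compounds, and the source may have more. Where it says the series, first, only, none or still open, it means among the compounds named here.

Of the compounds shown here, three sharing one core have been measured in a functional assay on KBVIN cells (Homo sapiens) for cytotoxicity, read by MTT assay, with a stated time of 72 h; on this read-out higher numbers stand for an effect only at larger amounts of compound and lower numbers for an effect already at smaller amounts. Compound 1 (`CCc1cccc2c(OC)c(-c3occ(C)c3C(=O)OC)ccc12`) gives 1.3 ug/mL as the methoxycarbonyl member, compound 2 (`CCOC(=O)c1c(C)coc1-c1ccc2c(CC)cccc2c1OC`) gives 1.8 ug/mL as the ethoxycarbonyl member, and compound 3 (`CCc1cccc2c(OC)c(-c3occ(C)c3CO)ccc12`) gives 6.6 ug/mL with hydroxymethyl in that place. The standing of compound 2 is fixed by two steps, a 1.4-fold higher number from compound 1 to compound 2 (0.14 log units; within the scatter) on one side and a 3.7-fold higher number from compound 2 to compound 3 (0.56 log units; beyond the scatter) on the other. Compound 4 (`CCc1cccc2c(OC)c(-c3occ(C)c3COCC(F)(F)F)ccc12`) has not yet been measured: (2,2,2-trifluoroethoxy)methyl in place of ethoxycarbonyl on an aromatic carbon describes its change from compound 2, namely (2,2,2-trifluoroethoxy)methyl in place of ethoxycarbonyl on an aromatic carbon. The nearest measured change also removes the ester, and replacing it with hydroxymethyl gave a 3.7-fold higher number from compound 2 to compound 3 (0.56 log units; beyond the scatter) and a 5.1-fold higher number from compound 1 to compound 3 (0.71 log units; beyond the scatter) as modest steps. No ether has been measured in this series, so a step of similar or smaller size, toward a higher number, is expected in this assay for this change. The expected step is a 1.9-fold higher number from compound 2 to compound 4 (0.29 log units; within the scatter) on this estimate. Compound 4 is thus estimated at 3.5 ug/mL (expected range 1.4 ug/mL to 9 ug/mL).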

Compound 4, concentration for half-maximal effect: 6 ug/mL
Estimate against measurement, compound 4: 1.7-fold (0.23 log units) below; the measured number falls inside the stated range.
By their numbers in this assay, from the lowest: compounds 1 and 2 (each within the scatter of the next); then compounds 4 and 3 (each within the scatter of the next).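

In this assay, turning the hydroxymethyl of the earlier series into (2,2,2-trifluoroethoxy)methyl, at this place on the five-membered aromatic ring, gives a 1.1-fold lower number from compound 3 to compound 4 (0.04 log units; within the scatter) and so no separable change, which means that the hydroxyl hydrogen can be capped here without a readable effect. The ether stands apart from both esters, with a 3.3-fold higher number from compound 2 to compound 4 (0.52 log units; beyond the scatter) and a 4.6-fold higher number from compound 1 to compound 4 (0.66 log units; beyond the scatter) as steps beyond the scatter, so in these four compounds the two esters form one group and the two compounds without the ester form another. Nothing available explains this division.

On these data alone, it remains open whether a carboxylic acid or an amide at this place would fall with the esters or with compound 3 and compound 4. Also open, as far as these compounds go, is whether a plain ethoxymethyl group or a longer chain on the ether oxygen would read any differently from compound 4.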